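Nitro in place of chloro on the anilide ring

The compounds below may be only part of what the source reports. "The series", "measured", "known", "first", "only" and "open" are said of these compounds alone.

Compound 3 `CC(=O)Nc1ccc(OCc2nnc(SCC(=O)Nc3ccc(Cl)cc3)n2Cc2ccccc2)cc1` gives 14 ug/mL in a toxicity assay on MT4 cells (Homo sapiens) for cytotoxicity, read by MTT assay, with a stated time of 5 days (on this read-out higher numbers stand for lower toxicity in this test and lower numbers for higher toxicity in this test), the highest of the two numbers at hand. Compound 1 `Cc1ccc(C(C)C)c(OCc2nnc(SCC(=O)Nc3ccc([N+](=O)[O-])cc3)n2Cc2ccccc2)c1` gives 11.2 ug/mL in this assay, a value within the scatter of compound 3. Compound 2 `CC(=O)Nc1ccc(OCc2nnc(SCC(=O)Nc3ccc(S(N)(=O)=O)cc3)n2Cc2ccccc2)cc1` reaches only a limit of the assay, > 125 ug/mL in this assay. Among the measured compounds shown here, the single step measured in one place, an at least 8.9-fold lower number from compound 2 to compound 3 (0.95 log units; beyond the scatter), rests on the limit of > 125 ug/mL in this assay, at which 1 of the 3 values shown sits, and is therefore known only as a lower bound.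

The change to compound 4 `CC(=O)Nc1ccc(OCc2nnc(SCC(=O)Nc3ccc([N+](=O)[O-])cc3)n2Cc2ccccc2)cc1` is nitro in place of chloro on an aromatic carbon. For the measured compounds named here, no measured step exchanges chloro for nitro; the sulfamoyl-to-chloro step bears on it only in that its chloro end is compound 3 itself. Compound 1 also carries nitro, though it differs elsewhere, and its number sits within the scatter of compound 3. A step of a 1.2-fold lower number from compound 3 to compound 4 (0.07 log units; within the scatter) is therefore expected, none beyond the scatter. Compound 4 is estimated at 12 ug/mL, between 5 ug/mL and 30 ug/mL.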

Compound 4, half-maximal cytotoxic concentration: 105 ug/mL
Beside the measured number, compound 4's estimate is 8.8-fold (0.94 log units) below it, outside the stated range (above it).
By their numbers in this assay, from the lowest: compounds 1 and 3 (each within the scatter of the next); then compound 4. At a limit, above all of these: compound 2.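

On the anilide ring, at the place para to a large group, nitro in place of chloro in this assay gives a 7.5-fold higher number from compound 3 to compound 4 (0.88 log units; beyond the scatter), a modest step. With the 4-nitrophenyl anilide held constant, 4-acetamidophenyl in place of 2-isopropyl-5-methylphenyl on the ether oxygen gives a 9.4-fold higher number from compound 1 to compound 4 (0.97 log units; beyond the scatter), so in these compounds nitro does not set the number alone and the ether aryl group matters as well. The step of an at least 1.1-fold lower number from compound 2 to compound 4 (0.07 log units; that floor lies within the scatter) gives only a floor and cannot be read further, since it rests on a limit: the limit of > 125 ug/mL in this assay, at which 1 of the 4 values shown sits.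

Open, on these data alone, is whether the nitro-for-chloro step keeps its size and direction with 2-isopropyl-5-methylphenyl on the ether oxygen. Also open, as far as these compounds go, is where other groups at this anilide place, such as an amine, a carboxylic acid or methoxy, would fall.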